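Sulfamoyl in place of methoxy: what to expect

The source may report more compounds than this note shows. Statements on the series, on what has been measured and on what is new or still open speak of the compounds shown alone.

Compound 1 `COc1cccc(Nc2nccc(-c3ccncc3)n2)c1` gives 400 nM in a functional assay for inhibition, with Homo sapiens as the target (a higher number here means a weaker inhibitor, a lower number a stronger inhibitor), the second highest number among the measured compounds. Compound 2 `COc1cccc(Nc2nccc(-c3cccnc3)n2)c1` gives 300 nM and compound 3 `COc1cccc(Nc2nccc(-c3cc(C)oc3C)n2)c1` gives 5800 nM; the step of a 1.3-fold lower number from compound 1 to compound 2 (0.12 log units; within the scatter) lies within the scatter, whereas a 15-fold higher number from compound 1 to compound 3 (1.16 log units; beyond the scatter) and a 19-fold higher number from compound 2 to compound 3 (1.29 log units; beyond the scatter) are large. Compound 4 `NS(=O)(=O)c1cccc(Nc2nccc(-c3ccncc3)n2)c1` differs from compound 1 by sulfamoyl in place of methoxy on an aromatic carbon. For the measured compounds named here, none of the measured steps touches this part of the shared core; all of them exchange the ring on the other side, so they give no direct guide for this change. The step of a 1.6-fold lower number from compound 1 to compound 4 (0.20 log units; within the scatter) is therefore expected to be small, not clearly beyond the scatter. Compound 4 is estimated in this assay at 250 nM, with a range from 60 nM to 1000 nM.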

Compound 4, half-maximal inhibitory concentration: 500 nM
Beside the measured number, compound 4's estimate is 2.0-fold (0.30 log units) below it, and the stated range covers the measured number.
By their numbers in this assay, from the lowest: compounds 2, 1 and 4 (each within the scatter of the next); then compound 3.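

In this assay, for the compounds shown here, sulfamoyl in place of methoxy on an aromatic carbon meta to a large group gives a 1.3-fold higher number from compound 1 to compound 4 (0.10 log units; within the scatter) and is the only reading at this position, since the earlier steps all exchanged the ring on the other side. This position therefore tolerates a group with more heavy atoms and a hydrogen-bond donor, which methoxy lacks, without a change beyond the scatter. Nothing shown accounts for this outcome. From the compounds shown here alone, whether an amine, a carboxylic acid or a longer chain would read alike here remains open. So does whether sulfamoyl would read the same with pyridin-3-yl or 2,5-dimethylfuran-3-yl in place of pyridin-4-yl.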